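A few compounds are considered here, and "the series" means these few. Any claim that something is new, unique, unknown or untested is made for them only; others in the source may bear on it.

Measured so far in a functional assay on NCI-H460 cells (Homo sapiens) for cytotoxicity, read by MTT assay, with a stated time of 72 h; a lower number here means a stronger inhibitor, a higher number a weaker inhibitor:
- compound 1, `CN(C)CCn1cnnc1-c1cc(Oc2ccc(NC(=O)N/N=C/c3ccccc3O[N+](=O)[O-])cc2F)ccn1`: 1270 nM
- compound 2, `CN(C)CCn1cnnc1-c1cc(Oc2ccc(NC(=O)N/N=C/c3ccccc3)cc2F)ccn1`: 1780 nM
- compound 3, `CN(C)CCn1cnnc1-c1cc(Oc2ccc(NC(=O)N/N=C/c3ccc(F)cc3F)cc2F)ccn1`: 1930 nM

Compound 3 gives the highest of the three numbers, but its separation from the others is small: a 1.1-fold higher number from compound 2 to compound 3 (0.04 log units; within the scatter) and a 1.5-fold higher number from compound 1 to compound 3 (0.18 log units; within the scatter). The third pair is likewise flat, a 1.4-fold higher number from compound 1 to compound 2 (0.15 log units; within the scatter). Within this set, exchanges on the aryl group attached to the carbon with a double bond to nitrogen have not moved this assay beyond the scatter.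

Compound 4, `COc1cc(/C=N/NC(=O)Nc2ccc(Oc3ccnc(-c4nncn4CCN(C)C)c3)c(F)c2)cc(OC)c1OC`, differs from compound 3 in the same position: 3,4,5-trimethoxyphenyl in place of 2,4-difluorophenyl on a carbon with a double bond to nitrogen. All three measured steps bear on this, being exchanges of the same aryl group, and each of them stayed within the scatter. Among the measured compounds shown here, no measured step introduces a methoxy-bearing ring, so the direction is not anchored; the expectation is nonetheless a step of no size beyond the scatter, a 1.1-fold lower number from compound 3 to compound 4 (0.03 log units; within the scatter), with a widened range to reflect the untested group. For compound 4 in this assay the estimate is 1800 nM, between 600 nM and 5500 nM.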

Compound 4, half-maximal inhibitory concentration: 2770 nM
Beside the measured number, compound 4's estimate is 1.5-fold (0.19 log units) below it, and the stated range covers the measured number.
By their numbers in this assay, from the lowest: compounds 1, 2, 3 and 4 (each within the scatter of the next, the first and the last beyond it).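

In this assay, among the compounds shown here, 3,4,5-trimethoxyphenyl on the carbon with a double bond to nitrogen gives the first exchange at this position to pass the scatter (a 2.2-fold higher number from compound 1 to compound 4 (0.34 log units; beyond the scatter)), a modest step seen only against 2-(nitrooxy)phenyl. Against the other two aryl groups the same group stays within the scatter (a 1.4-fold higher number from compound 3 to compound 4 (0.16 log units; within the scatter); a 1.6-fold higher number from compound 2 to compound 4 (0.19 log units; within the scatter)), so the position accepts a ring with three methoxy groups without a clear separation from phenyl or 2,4-difluorophenyl. For the compounds shown here, nothing available explains the one step that passes the scatter.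

Open, as far as these compounds go, is whether an amine or a carboxylic acid on this aryl ring would produce a larger step in either direction. Also open, from the compounds shown here alone, is whether a saturated cyclohexyl ring in place of the aryl group would do so.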